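The source may hold more compounds than are shown below. What is called first, only, known or untested is meant among the compounds shown, and "the series" means these compounds.

Measured in a functional assay on A2780 cells (Homo sapiens) for antiproliferative activity, read by fluorescence, with a stated time of 72 h; a higher number here means a weaker inhibitor, a lower number a stronger inhibitor
Compound 1 `CN1CCC(C(=O)N2Cc3c(NC(=O)C4CC4)n[nH]c3C2(C)C)CC1` gives 1420 nM
Compound 2 `CN1CCC(C(=O)N2Cc3c(NC(=O)c4ccsc4)n[nH]c3C2(C)C)CC1` gives 140 nM
Compound 3 `CN1CCC(C(=O)N2Cc3c(NC(=O)c4ccco4)n[nH]c3C2(C)C)CC1` gives > 5000 nM (a limit of the assay, not a number)

Compound 3 has no number on this scale, only a limit (the limit of > 5000 nM in this assay, at which 1 of the 3 values shown sits). The next compound to read is compound 4 `CCCNC(=O)Nc1n[nH]c2c1CN(C(=O)C1CCN(C)CC1)C2(C)C`, and the change is propylamino in place of furan-2-yl on a carbonyl carbon in the shared core's side chain: propylamino in place of furan-2-yl on a carbonyl carbon.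

All three measured steps are changes on this same carbonyl carbon, and all lie beyond the scatter. Two are large (a 10-fold lower number from compound 1 to compound 2 (1.01 log units; beyond the scatter) and an at least 35-fold higher number from compound 2 to compound 3 (1.55 log units; beyond the scatter)), and one is at least modest (an at least 3.5-fold higher number from compound 1 to compound 3 (0.54 log units; beyond the scatter)). So this place clearly moves the number, but none of the three compounds carries propylamino, and the direction of any new step is poorly fixed. Compound 1 (1420 nM) is taken as the nearest guide, as its group is the only non-aromatic one measured here. A step to a lower number is therefore expected (an at least 3.3-fold lower number from compound 3 to compound 4 (0.52 log units; beyond the scatter)) in this assay, of modest size and with a real chance of staying at the limit. Estimated for compound 4: 1500 nM (expected range 400 nM to 5000 nM).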

Compound 4, half-maximal inhibitory concentration: 650 nM
Compound 4: middle estimate off by 2.3-fold (0.36 log units), on the high side, and the stated range covers the measured number.
By their numbers in this assay, from the lowest: compound 2; then compound 4; then compound 1. At a limit, above all of these: compound 3.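

In this assay, propylamino on this carbonyl carbon gives a chain-bearing compound that sits inside the range set by the earlier groups, with a 2.2-fold lower number from compound 1 to compound 4 (0.34 log units; beyond the scatter) and a 4.6-fold higher number from compound 2 to compound 4 (0.67 log units; beyond the scatter). Compound 3 has only a limit of the assay, not a number: the limit of > 5000 nM in this assay, at which 1 of the 4 values shown sits. Measured against that limit, the change gives an at least 7.6-fold lower number from compound 3 to compound 4 (0.88 log units; beyond the scatter), so the two five-membered aromatic rings, thiophen-3-yl in compound 2 and furan-2-yl in compound 3, now stand on opposite sides of compound 4, and an aromatic ring alone does not set the order at this position.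

The compounds shown leave open whether the gain of compound 4 over compound 1 follows the nitrogen of propylamino or the length of its chain, which ethylamino, butylamino or a plain butyl group on the same carbonyl carbon would help to separate. They also leave open whether the wide gap between compound 2 and compound 3 follows the ring hetero atom or the point of attachment, which thiophen-2-yl and furan-3-yl would settle.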